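The compounds below may be only part of what the source reports. "The series", "measured", "known", "first", "only" and "open" are said of these compounds alone.

The shared core of the series is carried by compound 1 `CCC(=O)Oc1ccc(C(=O)C2=C3OC(C)(C)[C@@H](CC=C(C)C)C[C@@]34C[C@@H](CC=C(C)C)C(C)(C)[C@H]3CCC(C)(C)O[C@]34OC2=O)cc1OC(=O)CC`, which in a functional assay on HeLa cells (Homo sapiens) for antiproliferative activity, read by MTT assay, with a stated time of 72 h (on this read-out higher numbers stand for weaker inhibition and lower numbers for stronger inhibition), gives 15400 nM. Compound 2 `CCC(=O)Oc1cc(C(=O)C2=C3OC(C)(C)[C@@H](CC=C(C)C)C[C@@]34C[C@@H](CC=C(C)C)C(C)(C)[C@H]3CCC(C)(C)O[C@]34OC2=O)ccc1O` has hydrogen in place of propanoyl on an oxygen on an aromatic ring, and in this assay compound 2 gives only a limit of the assay, > 20000 nM. The step between them is an at least 1.2-fold higher number from compound 1 to compound 2 (0.11 log units; that floor lies within the scatter). Compound 3 `COc1ccc(C(=O)Oc2ccc(C(=O)C3=C4OC(C)(C)[C@@H](CC=C(C)C)C[C@@]45C[C@@H](CC=C(C)C)C(C)(C)[C@H]4CCC(C)(C)O[C@]45OC3=O)cc2OC(=O)c2ccc(OC)cc2)cc1` likewise gives only a limit in this assay, > 20000 nM. Compound 2 thus stands at the limit rather than at a number, and one further value shown is also a limit; this is the limit of > 20000 nM in this assay, at which 2 of the 3 values shown sit.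

Compound 4 `CCCCCC(=O)Oc1cc(C(=O)C2=C3OC(C)(C)[C@@H](CC=C(C)C)C[C@@]34C[C@@H](CC=C(C)C)C(C)(C)[C@H]3CCC(C)(C)O[C@]34OC2=O)ccc1O` differs from compound 2 by propyl in place of hydrogen on a saturated chain carbon, two bonds along the chain from a carbonyl carbon. Going by the values given here, no measured step lengthens the chain of this ester; the single measured step, an at least 1.2-fold higher number from compound 1 to compound 2 (0.11 log units; that floor lies within the scatter), concerns loss of the propanoyl group itself and sits at a floor within the scatter. Among the compounds with values here, nothing among the measured compounds therefore points to a change beyond the scatter, and with compound 2 at a limit the likely outcome for compound 4 is again a limit or a value close to it. The expected step is a step that the limit leaves unreadable from compound 2 to compound 4, taken as within the scatter. Compound 4 is estimated in this assay at 25000 nM, with a range from 12000 nM to 60000 nM.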

Compound 4, half-maximal inhibitory concentration: > 20000 nM
Compound 4 gave a limit, no number (the forecaster's own chance of this, stated with the estimate: 70%); the middle value lies beyond the limit too.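

In this assay compound 4 gives > 20000 nM, a limit of the assay. Compound 2 also sits at a limit, so no step can be read from compound 2 to compound 4, because neither value is a number: the limit of > 20000 nM in this assay, at which 3 of the 4 values shown sit.

The compounds shown leave open whether propanoyl and pentylcarbonyl differ at all in this assay on this scaffold.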